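The compounds below may be only part of what the source reports. "The series", "measured", "known", "first", "only" and "open" are said of these compounds alone.

Compound 1 `Cc1ccc(-c2ccc3[nH]c(=O)nc(-c4ccccc4)c3c2)cn1` is one of three members of a shared core measured in an ADME assay on L6 cells (Rattus norvegicus) for cytotoxicity, read by fluorescence and resazurin assay, with a stated time of 72 h; a lower number here means that less compound is needed, a higher number that more compound is needed for the effect. In this assay compound 1 gives > 50000 nM, which is a limit of the measurement and not a number, so compound 1 stands at the limit described by the limit of > 50000 nM in this assay, at which 1 of the 3 values shown sits, rather than at a measured value. Compound 2 `O=c1nc(-c2ccccc2)c2cc(-c3cnc4ccccc4c3)ccc2[nH]1` in this assay also gives only a limit, > 16000 nM. Among the compounds with values here, compound 3 `O=c1nc(-c2ccccc2)c2ccc(-c3cccnc3)cc2[nH]1` is the one member with a measured value in this assay, 7730 nM. Within the data shown here, no step between two measured compounds can be drawn from these three, because two of the three sit at limits, as the limit of > 16000 nM in this assay, at which 1 of the 3 values shown sits, and the limit of > 50000 nM in this assay, at which 1 of the 3 values shown sits, state.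

Compound 4 `O=c1nc(-c2ccccc2)c2cc(N3CCNCC3)ccc2[nH]1` differs from compound 1 by piperazin-1-yl in place of 6-methylpyridin-3-yl on an aromatic carbon. Among the measured compounds shown here, since compound 1 sits at a limit, no measured step exists to guide the size of the change in this assay; the three values together suggest compound 4 is expected to remain weakly cytotoxic, with any step from compound 1 to compound 4 expected to be small or within the scatter, as an at least 1.6-fold lower number from compound 1 to compound 4 (0.22 log units; that floor lies within the scatter) expresses. Compound 4 is therefore estimated at 30000 nM, with a range from 8000 nM to 100000 nM, in this assay.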

Compound 4, half-maximal effective concentration: > 25000 nM
Compound 4: no number, only a limit; the forecaster's own chance of this, stated with the estimate: 50%; the middle value is on the limit's open side.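

In this assay compound 4 gives > 25000 nM, which is a limit and not a number. Within the data shown here, compound 1 also stands at a limit, and no step from compound 1 to compound 4 can be read. The compounds shown leave open whether piperazin-1-yl in place of 6-methylpyridin-3-yl changes the value at all.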